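This account rests on a few compounds, and the source may have more. Where it says the series, first, only, none or still open, it means among the compounds named here.

Measured so far in a functional assay on the whole organism (strain ICR) for inhibition, with Mus musculus as the target, read by scintillation counting, with a stated time of 16 h, at a dose of 10 mg/kg by the oral route; on this read-out lower numbers stand for less inhibition and higher numbers for more inhibition at the one dose given (going by the name of the read-out):
- compound 1, `Cn1c(-c2ccc(-c3cncnc3)cc2)nnc1C1(c2ccc(Cl)cc2)CCC1`: -4%
- compound 2, `Cn1c(-c2ccc(C(N)=O)cc2C(N)=O)nnc1C1(c2ccc(Cl)cc2)CCC1`: 0%
- compound 3, `CCNC(=O)c1ccc(-c2nnc(C3(c4ccc(Cl)cc4)CCC3)n2C)cc1`: 0%

Compound 3 stands level with compound 2 at the digits given, and these two are together the highest of the three numbers, though the whole set sits at or just under zero. For the measured compounds named here, the one step measured between compounds differing in a single place, a number 4 percentage points higher from compound 1 to compound 3 (within the scatter), puts ethylcarbamoyl in place of pyrimidin-5-yl on an aromatic carbon and lies within the scatter. The values of compound 1 and compound 2 likewise show no gap beyond the scatter.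

Compound 4, `Cn1c(-c2ccc(C(=O)NC(C)(C)C)cc2)nnc1C1(c2ccc(Cl)cc2)CCC1`, keeps the core of compound 3 and its carbamoyl group and alters only what sits on the amide-type nitrogen: tert-butyl in place of ethyl on an amide-type nitrogen. Going by the values given here, no measured step touches that nitrogen. The step that bears on it most nearly is a number 4 percentage points higher from compound 1 to compound 3 (within the scatter), in which the ethylcarbamoyl group was itself brought in without a change beyond the scatter. With the series flat in this assay, the expected step is none beyond the scatter, no change at the digits printed from compound 3 to compound 4 (within the scatter). Compound 4 is estimated at 0%, with a range from -10% to 10%.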

Compound 4, a percentage reported as inhibition, in the whole organism at one dose (the size of the read-out at that dose, not a potency): 5%
Compound 4: middle estimate off by 5 percentage points, on the low side; measured number inside the range.
By their numbers in this assay, from the lowest: compounds 1, 2, 3 and 4 (each within the scatter of the next).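

For the compounds shown here, the first measured change on the amide-type nitrogen, tert-butyl in place of ethyl, gives in this assay a number 5 percentage points higher from compound 3 to compound 4 (within the scatter). This shows that the read-out at this one dose does not move beyond the scatter when the ethyl group on this nitrogen gives way to tert-butyl, and compound 4 stands at 5%. The wider exchange on the aromatic carbon, (tert-butyl)carbamoyl in place of pyrimidin-5-yl, gives a number 9 percentage points higher from compound 1 to compound 4 (within the scatter), so neither this exchange nor the earlier one with ethylcarbamoyl separates from the scatter, and nothing measured here offers an account of these numbers.

Still open, on these data alone, is whether any group on this nitrogen can lift the read-out in this assay beyond the scatter, for instance a longer chain ending in a primary amine or in a carboxylic acid. Also open is what a carboxylic acid would do on the aromatic carbon in place of the whole carbamoyl group, since every compound shown keeps the shared core and varies only this substituent.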